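The compounds below may be only part of what the source reports. "The series", "measured", "known", "first", "only" and "open" are said of these compounds alone.

Measured in a functional assay on DU-145 cells (Homo sapiens) for inhibition, read by trypan blue exclusion, with a stated time of 96 h; a higher number here means a weaker inhibitor of growth, a lower number a stronger inhibitor of growth:
- Compound 1 `CN(C)c1ccc(/C=C(/SCc2ccc(Cl)cc2)C(=O)c2ccc(C(=O)O)cc2)cc1`: 1000 nM
- Compound 2 `Cc1ccc(S(=O)(=O)/C(=C/c2ccc(N(C)C)cc2)C(=O)c2ccc(Cl)cc2)cc1`: > 100000 nM (a limit of the assay, not a number)
- Compound 3 `Cc1ccc(C)c(/C=C(/SCc2ccc(Cl)cc2)C(=O)c2ccc(Cl)cc2)c1`: 10000 nM

Of the two true numbers, compound 3 has the higher, at 10000 nM. Compound 1 lies lower at 1000 nM, a gap beyond the usual scatter. Compound 4 `CN(C)c1ccc(/C=C(/SCc2ccc(Cl)cc2)C(=O)c2ccc(Cl)cc2)cc1` keeps the rest of compound 3 and changes one group: 4-(dimethylamino)phenyl in place of 2,5-dimethylphenyl on a double-bonded chain carbon bound to a double-bonded chain carbon.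

Within the data shown here, no measured pair isolates this change, so any forecast is uncertain. Compound 1 carries the entering group and gives 1000 nM, which points to a lower number in this assay. Compound 2 also carries that group and goes against this hint. Its > 100000 nM is a limit. A moderate gain beyond the scatter is therefore expected, with the estimated step of a 5.0-fold lower number from compound 3 to compound 4 (0.70 log units; beyond the scatter). For compound 4 the estimated value is 2000 nM, with an expected range of 300 nM to 10000 nM.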

Compound 4, concentration for 50% growth inhibition: > 100000 nM
Compound 4 gave a limit, no number; the forecaster's own chance of this, stated with the estimate: 5%; middle value at least 50-fold (1.69 log units) away from the limit.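

In this assay, 4-(dimethylamino)phenyl in place of 2,5-dimethylphenyl gives an at least 10-fold higher number from compound 3 to compound 4 (1.00 log units; beyond the scatter), so the entering group does not by itself bring the stronger growth inhibition that compound 1 hinted at. Chloro in place of carboxy on an aromatic carbon gives an at least 100-fold higher number from compound 1 to compound 4 (2.00 log units; beyond the scatter), and among these compounds 4-(dimethylamino)phenyl comes with a true number only when carboxy is present, as in compound 1. Compound 4 sits at a limit, not a number, so both steps are minimum sizes, and its step from compound 2 cannot be read because both values are limits: the limit of > 100000 nM in this assay, at which 2 of the 4 values shown sit.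

From the compounds shown here alone, it remains open whether carboxy would have a similar effect alongside 2,5-dimethylphenyl. Going by these compounds, it is also open whether an amide or a methyl ester on that aromatic carbon would behave like carboxy.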